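A few compounds are considered here, and "the series" means these few. Any claim that something is new, unique, unknown or untested is made for them only; others in the source may bear on it.

Measured in an ADME assay on CEMx174 cells (Homo sapiens) for cytotoxicity; on this read-out higher numbers stand for lower toxicity in this test and lower numbers for higher toxicity in this test:
compound 1 `CCC1=C(C(=O)OCC2CCCCC2)C(c2cccc(O)c2)NC(=O)N1`: > 10000 nM
compound 2 `CCCC1=C(C(=O)OCC2CCCCC2)C(c2cccc(O)c2)NC(=O)N1`: > 10000 nM
compound 3 `O=C1NC(c2ccccc2)=C(C(=O)OCC2CCCCC2)C(c2cccc(O)c2)N1`: > 10000 nM

In this assay compound 1 gives > 10000 nM, which is a limit and not a number. Compound 2 gives > 10000 nM, also a limit. Compound 3 gives > 10000 nM, again a limit.

The next compound to be tested is compound 4 `CCC1=C(C(=O)OCC2CCCCC2)C(c2ccc([N+](=O)[O-])cc2)NC(=O)N1`, which keeps the ethyl group and the ester of compound 1. The change is 4-nitrophenyl in place of 3-hydroxyphenyl on a saturated ring carbon. Three measured steps exist in the series: a step that the two limits leave unreadable from compound 1 to compound 2, a step that the two limits leave unreadable from compound 1 to compound 3 and a step that the two limits leave unreadable from compound 2 to compound 3. Their sizes cannot be read because of the limit of > 10000 nM in this assay, at which 3 of the 3 values shown sit. All three alter the ethyl group or what replaces it, and none touches the saturated ring carbon where compound 4 differs, so they bear on this change only indirectly. They show that the group on the double-bonded ring carbon can vary while the 3-hydroxyphenyl stays in place, with the read-out remaining at the limit each time. Among the compounds with values here, no measured compound carries the 4-nitrophenyl group, so the expectation is weak, and no step beyond the scatter is expected in this assay. The expected result is a step that the limit leaves unreadable from compound 1 to compound 4. For compound 4 the estimated value is 12000 nM, with an expected range from 4000 nM to 40000 nM.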

Compound 4, half-maximal cytotoxic concentration: > 10000 nM
Compound 4 gave a limit, no number; the forecaster's own chance of this, stated with the estimate: 75%; the middle value is on the limit's open side.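

In this assay the result for compound 4 cannot be set against compound 1, and no step between them can be read, because both values are limits and not numbers: the limit of > 10000 nM in this assay, at which 4 of the 4 values shown sit.

The compounds shown leave open whether compound 1, compound 2, compound 3 and compound 4 differ at all in cytotoxicity, and whether any change to the shared core would bring a value inside the measurable range.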